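Azidomethyl to (carbamoylmethyl)sulfanyl on the sugar ring

This account rests on a few compounds, and the source may have more. Where it says the series, first, only, none or still open, it means among the compounds named here.

Measured so far:
compound 1 `[N-]=[N+]=NC[C@H]1O[C@H](CO)[C@@H](O)[C@H](O)[C@H]1O`, 22400000 nM
compound 2 `[N-]=[N+]=NC[C@@H]1O[C@H](CO)[C@@H](O)[C@H](O)[C@H]1O`, 15200000 nM

In an assay on isolated protein (Oryctolagus cuniculus) for inhibition of glycogen phosphorylase, brain form (Homo sapiens) (on this read-out lower numbers stand for stronger inhibition and higher numbers for weaker inhibition), compound 1 gives 22400000 nM, the highest of the two numbers; the nearest is compound 2, with a step of a 1.5-fold lower number from compound 1 to compound 2 (0.17 log units; within the scatter). The two compounds share all atoms and bonds and differ only in one stereocentre at a saturated ring carbon, a difference that may rest on (the fact that one of compounds 1 and 2 is drawn with a defined configuration and the other without, at the place where they differ). This single step is a change of drawn configuration and not an exchange of groups, so it does not bear directly on the change to compound 3 `NC(=O)CS[C@H]1O[C@H](CO)[C@@H](O)[C@H](O)[C@H]1O`.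

Compound 3 differs from compound 1 by (carbamoylmethyl)sulfanyl in place of azidomethyl on a saturated ring carbon. Among the measured compounds shown here, no measured step covers an exchange of this kind; the only known step is within the scatter and tells nothing about a substituent change. The expectation for compound 3 therefore rests on the structural change alone and carries a wide range. A step downward, to a lower number in this assay, is estimated, a 15-fold lower number from compound 1 to compound 3 (1.17 log units; beyond the scatter), but with little confidence in its size. Compound 3 is estimated at 1500000 nM, within 150000 nM to 15000000 nM.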

Compound 3, inhibition constant: 21100000 nM
Beside the measured number, compound 3's estimate is 14-fold (1.15 log units) below it; measured number above the stated range.
By their numbers in this assay, from the lowest: compounds 2, 3 and 1 (each within the scatter of the next).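

In this assay, the exchange of azidomethyl for (carbamoylmethyl)sulfanyl on the saturated ring carbon next to the ring oxygen gives a 1.1-fold lower number from compound 1 to compound 3 (0.03 log units; within the scatter). The earlier pair covered only a change of drawn configuration, whereas this step shows that a change of the substituent itself, with a sulfur atom, a carbonyl oxygen and a hydrogen-bond donor entering and the azide nitrogens leaving, also leaves the number of compound 3 within the scatter of that of compound 1, so the exchange gives no measurable gain or loss at this position. The information available on the series offers no explanation for this result.

Because azidomethyl and (carbamoylmethyl)sulfanyl differ in both the atom attached to the ring and the end of the chain, these compounds cannot separate the contribution of the sulfur link from that of the terminal amide. On these data alone, it remains open whether a carboxylic acid or an amine at the end of the chain, a longer chain, or an aromatic ring on the same sulfur link would move the number beyond the scatter.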